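The compounds below may be only part of what the source reports. "The series", "measured", "known", "first", "only" and "open" are said of these compounds alone.

Measured so far in an ADME assay on C8166 cells (Homo sapiens) for cytotoxicity, read by MTT assay; a lower number here means that less compound is tolerated, a higher number that more compound is tolerated:
- compound 1 `Cc1cccc(-n2cc(C(=O)O)c(=O)c3c(O)c(Cc4cccc(Cl)c4F)ccc32)c1` gives 71600 nM
- compound 2 `O=C(O)c1cn(Cc2cccc(F)c2)c2ccc(Cc3cccc(Cl)c3F)c(O)c2c1=O` gives 69000 nM

Of the two measured compounds, compound 2 stands at 69000 nM and lies within the scatter of compound 1, so the two cannot be ranked. Compound 3 `O=C(O)c1cn(Cc2ccc(F)c(F)c2)c2ccc(Cc3cccc(Cl)c3F)c(O)c2c1=O` differs from compound 2 by a single change, (fluoro in place of hydrogen on an aromatic carbon), which is fluoro in place of hydrogen on an aromatic carbon. This turns 3-fluorobenzyl into 3,4-difluorobenzyl, with the new fluoro ortho to a fluoro group and para to a large group.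

Among the compounds with values here, no measured step makes this exact change. Within the data shown here, the only step that bears on it is a 1.0-fold lower number from compound 1 to compound 2 (0.02 log units; within the scatter), in which 3-fluorobenzyl took the place of 3-methylphenyl on the same aromatic nitrogen. That single step is thin evidence, but it gives no reason to expect a shift beyond the scatter in this assay, and no direction is favoured. The estimated change is a 1.0-fold lower number from compound 2 to compound 3 (0.02 log units; within the scatter) and lies within the scatter. For compound 3 the expected value is 66000 nM, with an estimated range from 30000 nM to 135000 nM.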

Compound 3, half-maximal cytotoxic concentration: 71400 nM
For compound 3 the middle estimate is 1.1-fold (0.03 log units) below the measured one, within the range that was stated.
By their numbers in this assay, from the lowest: compounds 2, 3 and 1 (each within the scatter of the next).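

In this assay, within the data shown here, the first direct reading of a substitution on the benzyl ring itself is a 1.0-fold higher number from compound 2 to compound 3 (0.01 log units; within the scatter), so a fluoro on this aromatic carbon, ortho to a fluoro group and para to a large group, produces no step that can be told apart from repeat-measurement scatter. The group on the aromatic nitrogen can also be read in a second pairing, a 1.0-fold lower number from compound 1 to compound 3 (0.00 log units; within the scatter), which means that 3,4-difluorobenzyl and 3-methylphenyl cannot be ranked in this assay either. Across the three compounds, then, the 3-methylphenyl, 3-fluorobenzyl and 3,4-difluorobenzyl groups all sit within the scatter of one another, and nothing available explains this.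

What the compounds shown leave open is whether this position stays as insensitive with a group other than fluoro, such as an amine, a methoxy group or a longer alkyl chain. They also leave open whether any change to the group on the aromatic nitrogen can move the number in this assay beyond the scatter, since all the variation shown is confined to a small set of aromatic groups there.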